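Replacing an aminoester chain with a small aminomethyl group

The source may hold more compounds than are shown below. What is called first, only, known or untested is meant among the compounds shown, and "the series" means these compounds.

Compound 1, `CCCCCCc1c(F)c(N)c2c(=O)cc(-c3ccc(N)c(F)c3)oc2c1F`, in a functional assay on MCF7 cells (Homo sapiens) for cytotoxicity, read by neutral red uptake, with a stated time of 3 days; on this read-out lower numbers stand for stronger inhibition and higher numbers for weaker inhibition: > 10000 nM, which is a limit of the assay and not a number.
Compound 2, `C[S+]([O-])c1c(F)c(N)c2c(=O)cc(-c3ccc(N)c(F)c3)oc2c1F`, in this assay: 2500 nM.
Compound 3, `CN(C)CCC(=O)OCc1c(F)c(N)c2c(=O)cc(-c3ccc(N)c(F)c3)oc2c1F`, in this assay: 19 nM.

Among the numbers shown, compound 3 has the lowest; its nearest neighbour is compound 2, separated by a 130-fold lower number from compound 2 to compound 3 (2.12 log units; beyond the scatter). The three compounds share one core and differ only in the group on one aromatic carbon, so every step measured so far speaks to this position. The hexyl chain of compound 1 sits at the assay limit (the limit of > 10000 nM in this assay, at which 1 of the 3 values shown sits); the change to the methylsulfinyl group gives an at least 4.0-fold lower number from compound 1 to compound 2 (0.60 log units; beyond the scatter), and the change to the aminoester chain gives an at least 520-fold lower number from compound 1 to compound 3 (2.72 log units; beyond the scatter).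

Compound 4, `NCc1c(F)c(N)c2c(=O)cc(-c3ccc(N)c(F)c3)oc2c1F`, is not yet measured. It differs from compound 3 by amino in place of ((2-(dimethylamino)ethyl)carbonyl)oxy on a saturated chain carbon bound to an aromatic carbon. The change strips most of the chain that accompanied the large improvements in the two steps above, and what remains is a single nitrogen on the chain carbon. The expectation is therefore a number higher than that of compound 3, with a step of roughly a 5.3-fold higher number from compound 3 to compound 4 (0.72 log units; beyond the scatter), though a small basic group has not been tested here and the uncertainty is wide. Compound 4 is expected to give about 100 nM, within a range from 10 nM to 1000 nM.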

Compound 4, half-maximal inhibitory concentration: 26 nM
Estimate against measurement, compound 4: 3.8-fold (0.59 log units) above; measured number inside the range.
By their numbers in this assay, from the lowest: compounds 3 and 4 (each within the scatter of the next); then compound 2. At a limit, above all of these: compound 1.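

In this assay, almost all of the aminoester chain turns out to be dispensable at this position: cutting it back from (((2-(dimethylamino)ethyl)carbonyl)oxy)methyl to aminomethyl gives a 1.4-fold higher number from compound 3 to compound 4 (0.14 log units; within the scatter) and so leaves the two compounds indistinguishable, even though only a single nitrogen remains on the chain carbon. The small group also keeps large steps over the other two groups, with a 96-fold lower number from compound 2 to compound 4 (1.98 log units; beyond the scatter) on leaving the methylsulfinyl group and an at least 380-fold lower number from compound 1 to compound 4 (2.58 log units; beyond the scatter) on leaving the hexyl chain. Compound 1 stands at a limit of the assay and not at a number: the limit of > 10000 nM in this assay, at which 1 of the 4 values shown sits.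

On these data alone, what remains open is whether the nitrogen itself matters or only the short chain, a question that a hydroxymethyl group or a plain methyl group in the same place would address. Also open, as far as these compounds go, is how far the chain and its amine can vary in this assay, for instance with a 2-aminoethyl group or a dimethylaminomethyl group.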